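Methoxy for Chloro on a Shared Pyrazoline-Type Core

The source may hold more compounds than are shown below. What is called first, only, known or untested is meant among the compounds shown, and "the series" means these compounds.

Of the compounds shown here, two have been measured in an assay on isolated protein for inhibition of Amine oxidase [flavin-containing] A (Bos taurus); on this read-out lower numbers stand for stronger inhibition and higher numbers for weaker inhibition. Compound 1 `CCC(=O)N1N=C(c2ccc(Cl)cc2)CC1c1ccc(Cl)cc1` gives 200 nM, the lowest of the two numbers. Compound 2 `CCC(=O)N1N=C(c2ccc(C)cc2)CC1c1ccc(C)cc1` gives 100000 nM, a much higher number, beyond the scatter. Compound 3 `CCC(=O)N1N=C(c2ccc(OC)cc2)CC1c1ccc(Cl)cc1` is not yet measured; it differs from compound 1 by methoxy in place of chloro on an aromatic carbon, in words methoxy in place of chloro on an aromatic carbon. For the measured compounds named here, no measured step shows this change, so the expected step of a 10-fold higher number from compound 1 to compound 3 (1.00 log units; beyond the scatter) rests on compound 2 alone, whose weaker result in this assay is 100000 nM. Compound 3 is therefore expected to give 2000 nM, likely between 300 nM and 15000 nM.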

Compound 3, half-maximal inhibitory concentration: 832 nM
Compound 3: the middle estimate sits 2.4-fold (0.38 log units) above what was measured; the measured number falls inside the stated range.
By their numbers in this assay, from the lowest: compound 1; then compound 3; then compound 2.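

In this assay the one-place change from 4-chlorophenyl to 4-methoxyphenyl gives a 4.2-fold higher number from compound 1 to compound 3 (0.62 log units; beyond the scatter) and so costs only a modest amount of inhibition. For the compounds shown here, this is the only direct reading at this position, and it shows that methoxy is accepted there while the second 4-chlorophenyl stays in place. Nothing available explains the size of this step. The compounds shown leave open how fluoro or an amine would read at this position, and whether methoxy on the second ring would give a similar step.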